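The compounds below may be only part of what the source reports. "The series", "measured", "known", "first", "only" and "open" are said of these compounds alone.

Within the data shown here, compound 2 `O=C1N=C(N2N=C(c3ccccc3)CC2c2ccc(Cl)cc2)S/C1=C1/C(=O)Nc2ccccc21` stands lowest of the two numbers so far: in a functional assay on cells (Cancer cell lines, Homo sapiens) for cytotoxicity, read by sulforhodamine B assay, with a stated time of 48 h (on this read-out higher numbers stand for weaker inhibition of growth and lower numbers for stronger inhibition of growth), compound 2 gives 190 nM, whereas compound 1 `O=C1N=C(N2N=C(c3ccccc3)CC2c2ccccc2O)S/C1=C1/C(=O)Nc2ccccc21` gives 2130 nM. Among the measured compounds shown here, the single measured step, an 11-fold lower number from compound 1 to compound 2 (1.05 log units; beyond the scatter), concerns the substituent on the saturated ring carbon and not the fused aromatic ring. Compound 3 `Cc1ccc2c(c1)/C(=C1\SC(N3N=C(c4ccccc4)CC3c3ccc(Cl)cc3)=NC1=O)C(=O)N2` differs from compound 2 by methyl in place of hydrogen on an aromatic carbon. For the measured compounds named here, no measured step touches that position, so no change beyond the scatter is expected, and the step is estimated as no change at the digits printed from compound 2 to compound 3 (within the scatter). Compound 3 is therefore expected to give about 190 nM, within a range of 70 nM to 550 nM.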

Compound 3, concentration for 50% growth inhibition: 240 nM
For compound 3 the middle estimate is 1.3-fold (0.10 log units) below the measured one; the range from low to high includes it.
By their numbers in this assay, from the lowest: compounds 2 and 3 (each within the scatter of the next); then compound 1.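

In this assay, methyl in place of hydrogen on an aromatic carbon gives a 1.3-fold higher number from compound 2 to compound 3 (0.10 log units; within the scatter) and so shows that this position takes a methyl with no shift beyond the scatter. Among these compounds, this is the first measured step on that ring, as the earlier step concerned only the saturated ring carbon. No available evidence bears on this result. On these data alone, whether an amine, a carboxylic acid or a longer chain at this position would behave the same remains open. Also open, as far as these compounds go, is whether the methyl result holds with 2-hydroxyphenyl on the saturated ring carbon.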